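The source may report more compounds than this note shows. Statements on the series, on what has been measured and on what is new or still open speak of the compounds shown alone.

Measured compounds in a functional assay on the whole organism for inhibition, with Mus musculus as the target, at a dose of 10 mg/kg by the oral route; a higher number here means more inhibition at the dose given (going by the name of the read-out), a lower number less inhibition:
- compound 1, `COc1ccc(-c2ccc(Cl)cc2)c2cc(C(=O)Nc3ccc(Cn4ccnc4)cc3)oc12`: "not determined" (no result reported)
- compound 2, `COC(=O)c1ccc(OC)c2oc(C(=O)Nc3ccc(OC)cc3)cc12`: "not determined" (no result reported)
- compound 3, `COc1ccc(-c2ccccc2)c2cc(C(=O)Nc3ccc(Cn4ccnc4)cc3)oc12`: 12%

Among the measured compounds shown here, compound 3 is the only entry with a number in this assay. Compound 1 and compound 2 have no result reported, so compound 3 stands alone and no ordering among the three can be drawn. For compound 3 the reading of 12% is a small inhibition at the dose used.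

Compound 4, `COC(=O)c1ccc(OC)c2oc(C(=O)Nc3ccc(Cn4ccnc4)cc3)cc12`, remains to be measured in this assay. It differs from compound 3 in one place: methoxycarbonyl in place of phenyl on an aromatic carbon. Compound 2 carries the same methoxycarbonyl-bearing core with a different amide partner, but no result exists for it, so the exchange has not been measured in any pair of the series. For the measured compounds named here, no step between measured compounds is available to set a size or a direction.

With only the low reading of compound 3 as an anchor, the expectation is that the change does not move the inhibition beyond the usual scatter in either direction. The expected step is a number 2 percentage points lower from compound 3 to compound 4 (within the scatter), within the scatter. Compound 4 is accordingly estimated at 10%, with a range from 0% to 30%.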

Compound 4, a percentage reported as inhibition, in the whole organism at one dose (the size of the read-out at that dose, not a potency): 0%
For compound 4 the middle estimate is 10 percentage points above the measured one, and the stated range covers the measured number.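

In this assay, the series now has its first readable step: methoxycarbonyl in place of phenyl, on the aromatic carbon para to a methoxy group, gives a number 12 percentage points lower from compound 3 to compound 4 (beyond the scatter). This shows that the reading responds to the group at this position while the rest of the structure stays the same, and that methoxycarbonyl does not retain the small inhibition seen with phenyl at the dose given. No measurement shown bears on the reason for this step.

Steps involving compound 1 and compound 2 cannot be read, so the effect of the chlorine on the phenyl ring and of the other amide partner remains unresolved. Going by these compounds, it also remains open whether the reading follows the presence of an aromatic ring here or is specific to methoxycarbonyl, and a carboxylic acid, a primary amide, a methyl group or a pyridine ring at the same carbon would help separate these possibilities.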